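This account rests on a few compounds, and the source may have more. Where it says the series, first, only, none or still open, it means among the compounds named here.

Two compounds share one core. Compound 1 `CNC(=O)/C=C1\CCc2ccc(Br)cc21` carries a methyl on its amide nitrogen; in a functional assay on the whole organism with Rattus norvegicus as the target, at a dose of 20 mg/kg by the oral route (a higher number here means more inhibition at the dose given (going by the name of the read-out), a lower number less inhibition), compound 1 gives 53%. Compound 2 `NC(=O)/C=C1\CCc2ccc(Br)cc21` has hydrogen in place of that methyl, and in this assay compound 2 gives 21%, the lowest of the two numbers shown. Within the data shown here, the only measured step is a number 32 percentage points lower from compound 1 to compound 2 (beyond the scatter). Compound 3 `COc1ccc2c(c1)/C(=C/C(N)=O)CC2` is not yet measured; it differs from compound 2 by methoxy in place of bromo on an aromatic carbon. That single measured step concerns the amide nitrogen, not the aromatic ring, so it does not bear on this change, and the aromatic substituent has not been varied among the measured compounds. Nothing here tells how exchanging bromo for methoxy moves the read-out, so the expected step of a number 1 percentage points lower from compound 2 to compound 3 (within the scatter) is none beyond the scatter. Starting from compound 2 and its 21%, compound 3 is therefore expected at 20%, with a range from 0% to 45%.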

Compound 3, a percentage reported as inhibition, in the whole organism at one dose (the size of the read-out at that dose, not a potency): 3%
The estimate for compound 3 lay 17 percentage points above the measured number, and the stated range covers the measured number.
By their numbers in this assay, from the lowest: compound 3; then compound 2; then compound 1.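

Among these compounds, the aromatic substituent had not been varied among the earlier compounds, and this change shows that it matters: in this assay methoxy in place of bromo on this aromatic carbon gives a number 18 percentage points lower from compound 2 to compound 3 (beyond the scatter) on the shared core. The read-out therefore responds to this aromatic carbon as well as to the amide nitrogen, and compound 3, at 3%, has the lowest number of the three. Nothing available explains why the swap lowers the number.

As far as these compounds go, whether the same swap would lower the number as much on the methyl amide of compound 1 remains open. Also open, from the compounds shown here alone, is how other groups on this aromatic carbon, such as chloro, an amine or a carboxylic acid, would compare with bromo.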